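The source may hold more compounds than are shown below. What is called first, only, known or untested is meant among the compounds shown, and "the series" means these compounds.

Measured in a functional assay on SGC-7901 cells (Homo sapiens) for antiproliferative activity, read by MTT assay, with a stated time of 72 h; on this read-out lower numbers stand for stronger inhibition and higher numbers for weaker inhibition:
- compound 1 `COc1ccc(-c2sc(C(=O)O)cc2-c2cc(OC)c(OC)c(OC)c2)cc1O` gives 6100 nM
- compound 2 `CCOC(=O)c1cc(-c2ccc(OC)cc2)c(-c2cc(OC)c(OC)c(OC)c2)s1` gives 6820 nM
- compound 3 `COc1ccc(-c2cc(C(=O)O)sc2-c2cc(OC)c(OC)c(OC)c2)cc1` gives 4220 nM

Compound 3, at 4220 nM, lies within the scatter of both compound 1 and compound 2, so the three values form a single band with no separation among them.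

The next change leads to compound 4 `COc1ccc(-c2cc(C(=O)O)sc2-c2cc(OC)c(OC)c(OC)c2)cc1OCc1ccccc1` and is described as benzyloxy in place of hydrogen on an aromatic carbon. It places benzyloxy in place of hydrogen on an aromatic carbon, ortho to a methoxy group.

Among the compounds with values here, the only measured step is a 1.6-fold lower number from compound 2 to compound 3 (0.21 log units; within the scatter). It lies within the scatter and concerns the group next to the carbonyl, so it says nothing direct about a benzyloxy group. Within the data shown here, no measured step covers a change of this kind, which leaves the direction open and the range wide.

In this assay, no step beyond the scatter is expected, and the estimated step is a 1.3-fold higher number from compound 3 to compound 4 (0.12 log units; within the scatter). The estimate for compound 4 is 5500 nM, with an expected range from 1800 nM to 17000 nM.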

Compound 4, half-maximal inhibitory concentration: > 100000 nM
Compound 4: a limit, no number; the forecaster's own chance of this, stated with the estimate: 8%; middle value at least 18-fold (1.25 log units) away from the limit.
By their numbers in this assay, from the lowest: compounds 3, 1 and 2 (each within the scatter of the next). At a limit, above all of these: compound 4.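

Compound 4 shows that this aromatic carbon, ortho to a methoxy group and meta to a large group, does not tolerate every substituent: benzyloxy in place of hydrogen gives an at least 23-fold higher number from compound 3 to compound 4 (1.37 log units; beyond the scatter) in this assay. Within the data shown here, this is the first step beyond the scatter, and the earlier compounds gave no sign of how sensitive this position is. The value of compound 4 is a limit and not a number, so the full size of the step stays unknown: the limit of > 100000 nM in this assay, at which 1 of the 4 values shown sits.

Going by these compounds, whether an ethoxy group or an amine at this carbon would stay with compound 3 remains open, and so does whether a cyclohexylmethoxy group would match benzyloxy. Also open, on these data alone, is whether benzyloxy at this carbon would have the same effect on the ethyl ester, compound 2.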